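Replacing the (2-aminoethyl)amino Group on the Carbonyl Carbon

The compounds below may be only part of what the source reports. "The series", "measured", "known", "first", "only" and "open" are said of these compounds alone.

In a functional assay on HepG2 cells (Homo sapiens), read by MTT assay, with a stated time of 48 h (a lower number here means a stronger inhibitor, a higher number a weaker inhibitor), compound 1 (`CCN(CC)CCNC(=O)c1ccc(C(CC)(CC)c2ccc(OCC(O)C(C)(C)C)c(C)c2)n1CC`) gives 490 nM, compound 2 (`CCn1c(C(=O)NCCCN(C)C)ccc1C(CC)(CC)c1ccc(OCC(O)C(C)(C)C)c(C)c1`) gives 360 nM and compound 3 (`CCn1c(C(=O)NCCN)ccc1C(CC)(CC)c1ccc(OCC(O)C(C)(C)C)c(C)c1`) gives 176 nM, the lowest number of the three. Among the compounds with values here, compound 4 (`CCn1c(C(=O)N(CCC#N)CCC#N)ccc1C(CC)(CC)c1ccc(OCC(O)C(C)(C)C)c(C)c1`) has no measurement yet. Its structural change from compound 3 sits on a carbonyl carbon: a group of 9 heavy atoms (6 carbon, 3 nitrogen; no ring) in place of a group of 4 heavy atoms (2 carbon, 2 nitrogen; no ring), on a carbonyl carbon. The entering group has no common name and holds 2 triple bonds outside aromatic rings.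

Within the data shown here, three measured steps bear on this change, since all of them alter the same chain on the amide nitrogen: a 1.4-fold lower number from compound 1 to compound 2 (0.13 log units; within the scatter), a 2.8-fold lower number from compound 1 to compound 3 (0.44 log units; beyond the scatter) and a 2.0-fold lower number from compound 2 to compound 3 (0.31 log units; beyond the scatter). They are small to modest. Compound 3 carries the smallest group of the three, and the two larger groups stand higher, with compound 2 at 360 nM and compound 1 at 490 nM. None of these compounds loses the amino end of the chain or the amide hydrogen, so the change to compound 4 goes beyond anything measured and the expectation is loose. A step to a higher number, somewhat larger than those seen so far, is expected in this assay. The expected step is a 5.1-fold higher number from compound 3 to compound 4 (0.71 log units; beyond the scatter). The estimated value for compound 4 is 900 nM, with an expected range of 300 nM to 3500 nM.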

Compound 4, half-maximal inhibitory concentration: 42000 nM
Compound 4: middle estimate off by 47-fold (1.67 log units), on the low side; the measured number lies above the stated range.
By their numbers in this assay, from the lowest: compound 3; then compounds 2 and 1 (each within the scatter of the next); then compound 4.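

In this assay the chain on the amide nitrogen proves far less tolerant than compound 1, compound 2 and compound 3 suggested: the entering group, with its 2 triple bonds outside aromatic rings and 0 hydrogen-bond donors, gives a 240-fold higher number from compound 3 to compound 4 (2.38 log units; beyond the scatter) and also a 120-fold higher number from compound 2 to compound 4 (2.07 log units; beyond the scatter) as well as an 86-fold higher number from compound 1 to compound 4 (1.93 log units; beyond the scatter) in this series. Heavy-atom count alone does not track these numbers, since the group in compound 1 is close in count to the one in compound 4 and yet that step is large, while the much bigger difference in count behind a 2.8-fold lower number from compound 1 to compound 3 (0.44 log units; beyond the scatter) is only modest. Nothing available here explains the rise.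

Compound 4 loses the amide hydrogen and the terminal amine together and gains two nitrile ends, so the compounds shown leave open which of these changes carries the loss. An amide with a single 2-cyanoethyl chain that keeps the amide hydrogen, or one with two 2-aminoethyl chains and no amide hydrogen, would separate these changes.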